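The compounds below may be only part of what the source reports. "The series", "measured", "known", "first", "only" and "open" are said of these compounds alone.

Of the compounds shown here, two have so far been measured in a functional assay on SK-OV-3 cells (Homo sapiens) for inhibition, with a stated time of 48 h; on this read-out lower numbers stand for stronger inhibition of growth and higher numbers for weaker inhibition of growth. Compound 1 `COc1c(C(=O)/C=C/c2ccc(Cl)cc2)c(O)c(Br)c2occc12` gives 1110 nM, and compound 2 `C=CCc1c(O)c(C(=O)/C=C/c2ccccc2)c(OC)c2ccoc12` gives 8080 nM. Compound 2 therefore has the higher of the two numbers, with a gap beyond the scatter. Compound 3 `C=CCc1c(O)c(C(=O)/C=C/c2ccc(Cl)cc2)c(OC)c2ccoc12` differs from compound 2 in one place: chloro in place of hydrogen on an aromatic carbon. This is chloro in place of hydrogen on an aromatic carbon, para to a large group, turning phenyl to 4-chlorophenyl. Among the measured compounds shown here, no measured pair shows this change alone. For the measured compounds named here, the only guide is compound 1, which carries the 4-chlorophenyl group on a differently substituted core and gives 1110 nM. A moderate shift toward stronger inhibition in this assay is expected, though it may barely clear the scatter. The expected step, a 2.3-fold lower number from compound 2 to compound 3 (0.36 log units; beyond the scatter), is only an estimate. For compound 3 the estimated value is 3500 nM, within a range of 1200 nM to 9000 nM.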

Compound 3, concentration for 50% growth inhibition: 5960 nM
Compound 3: middle estimate off by 1.7-fold (0.23 log units), on the low side, and the stated range covers the measured number.
By their numbers in this assay, from the lowest: compound 1; then compounds 3 and 2 (each within the scatter of the next).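

In this assay, turning phenyl to 4-chlorophenyl on the shared core gives a 1.4-fold lower number from compound 2 to compound 3 (0.13 log units; within the scatter), so at this place, para to a large group, chloro alone does not move the number beyond the scatter. With the 4-chlorophenyl group held in common, allyl in place of bromo on an aromatic carbon gives a 5.4-fold higher number from compound 1 to compound 3 (0.73 log units; beyond the scatter), so the clear gap among these chloro compounds goes with that other change. Nothing available explains either step.

As far as these compounds go, it remains open whether a different group at the para place, such as methoxy or an amine, would shift the number beyond the scatter. From the compounds shown here alone, it is also open how a longer chain or a carboxylic acid would compare with allyl and bromo on that aromatic carbon.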